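The source may report more compounds than this note shows. Statements on the series, on what has been measured and on what is new or still open speak of the compounds shown alone.

In a functional assay on MDA-MB-231 cells (Homo sapiens) for inhibition, read by MTT assay, with a stated time of 72 h (on this read-out higher numbers stand for weaker inhibition and lower numbers for stronger inhibition), compound 2 `Nc1ncnc2c1c(-c1cnc3[nH]ccc3c1)nn2CCCCCCC(=O)NO` gives 37700 nM, the only number shown. Compound 1 `Nc1ncnc2c1c(-c1cnc3[nH]ccc3c1)nn2CCCCC(=O)NO` gives > 50000 nM, which is a limit and not a number. Compound 3 `Nc1ncnc2c1c(-c1cnc3[nH]ccc3c1)nn2CCC(=O)NO`, not yet measured, differs from compound 2 by hydroxycarbamoyl in place of 4-(hydroxycarbamoyl)butyl on a saturated chain carbon, two bonds along the chain from an aromatic nitrogen, on a saturated chain carbon, two bonds along the chain from an aromatic nitrogen. Among the compounds with values here, one measured step bears on this change: an at least 1.3-fold lower number from compound 1 to compound 2 (0.12 log units; that floor lies within the scatter), where 2-(hydroxycarbamoyl)ethyl replaces hydroxycarbamoyl. That step is bounded only on one side, and it rests on (the limit of > 50000 nM in this assay, at which 1 of the 2 values shown sits). Compound 3 goes the opposite way from that step, and further, so a move to a higher number in this assay is expected, though none clearly beyond the scatter. The expected step is a 1.6-fold higher number from compound 2 to compound 3 (0.20 log units; within the scatter). The estimate for compound 3 is 60000 nM, within an expected range from 30000 nM to 150000 nM.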

Compound 3, half-maximal inhibitory concentration: > 150000 nM
Compound 3: no number, only a limit; the forecaster's own chance of this, stated with the estimate: 70%; at least 2.5-fold (0.39 log units) between middle value and limit.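

In this assay compound 3 gives > 150000 nM, which is a limit and not a number: the limit of > 150000 nM in this assay, at which 1 of the 3 values shown sits. Even so, cutting the chain back at this place, a saturated chain carbon two bonds along the chain from an aromatic nitrogen, with hydroxycarbamoyl in place of 4-(hydroxycarbamoyl)butyl, gives an at least 3.9-fold higher number from compound 2 to compound 3 (0.59 log units; beyond the scatter), so a change in chain length now shows beyond the scatter, which the earlier step between compounds did not. On these data alone, compound 1 and compound 3 both stand as limits, so the step between them cannot be read and their order stays unknown: the limit of > 50000 nM in this assay, at which 1 of the 3 values shown sits.

As far as these compounds go, compound 2 is the only one of the three with a number, so the full size of the change remains open. Also open, from the compounds shown here alone, is how a longer chain than that of compound 2 would read, or a carboxylic acid or an amine in place of hydroxycarbamoyl.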